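A few compounds are considered here, and "the series" means these few. Any claim that something is new, unique, unknown or untested is made for them only; others in the source may bear on it.

In an ADME assay on U-937 cells (Homo sapiens) for cytotoxicity, read by MTT assay, with a stated time of 72 h (a lower number here means that less compound is tolerated, a higher number that more compound is tolerated), three compounds have been measured:

- compound 1 `COc1ccc(/C=C/C(=O)OCCCCOc2cc(Cl)ccc2Oc2ccc(Cl)cc2Cl)cc1OC`: 73400 nM
- compound 2 `O=C(/C=C/c1ccc(O)c(O)c1)OCCCCCCCOc1cc(Cl)ccc1Oc1ccc(Cl)cc1Cl`: 20000 nM
- compound 3 `O=C(/C=C/c1ccc(O)c(O)c1)OCCCCCCCCCOc1cc(Cl)ccc1Oc1ccc(Cl)cc1Cl`: 3620 nM

Compound 1 has the highest number of the three, so it is the best tolerated in this assay. Its gaps to compound 2 and compound 3 both lie beyond the usual scatter.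

Compound 4 `O=C(/C=C/c1ccc(O)c(O)c1)OCCCCOc1cc(Cl)ccc1Oc1ccc(Cl)cc1Cl` has not yet been measured. It differs from compound 1 by one change: 3,4-dihydroxyphenyl in place of 3,4-dimethoxyphenyl on a double-bonded chain carbon bound to a double-bonded chain carbon. In words, it carries 3,4-dihydroxyphenyl in place of 3,4-dimethoxyphenyl on a double-bonded chain carbon bound to a double-bonded chain carbon.

Among the compounds with values here, no measured pair isolates this change. Compound 2 and compound 3 carry the 3,4-dihydroxyphenyl group of compound 4, but their chains differ from its chain, so they offer only indirect guidance. The lower numbers of compound 2, at 20000 nM, and compound 3, at 3620 nM, lean the expectation slightly downward. The expected change is small and probably within the scatter, with an estimated step of a 1.5-fold lower number from compound 1 to compound 4 (0.17 log units; within the scatter).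

Compound 4 is expected at 50000 nM, with an estimated range from 20000 nM to 120000 nM.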

Compound 4, concentration lethal to 50% of the cells: 12000 nM
Estimate against measurement, compound 4: 4.2-fold (0.62 log units) above; measured number below the stated range.
By their numbers in this assay, from the lowest: compound 3; then compounds 4 and 2 (each within the scatter of the next); then compound 1.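

In this assay, within the data shown here, this pair gives the first direct reading of the change: with the chain left the same, 3,4-dihydroxyphenyl in place of 3,4-dimethoxyphenyl, on a double-bonded chain carbon bound to a double-bonded chain carbon, brings a 6.1-fold lower number from compound 1 to compound 4 (0.79 log units; beyond the scatter). The earlier compounds shown here could not show this, since the only ones carrying 3,4-dihydroxyphenyl also had chains different from that of the sole 3,4-dimethoxyphenyl compound, so the exchange of these two groups could not be told apart from the chain; now it is seen to lower the tolerated concentration on its own, and compound 4 also stands within the scatter of compound 2 despite the longer chain of compound 2. Nothing available here bears on what lies behind this step.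

The compounds shown leave open whether the same step would appear on the longer chains of compound 2 and compound 3, which are known only with 3,4-dihydroxyphenyl. They also leave open how a phenyl carrying a single hydroxy group, or an amide in place of the ester, would read in this assay.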